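The source may hold more compounds than are shown below. What is called first, only, known or untested is meant among the compounds shown, and "the series" means these compounds.

Series notes, an ADME assay on Raji cells (Homo sapiens) for cytotoxicity, read by CellTiter-Glo and resazurin assay, with a stated time of 72 h; a lower number here means that less compound is needed, a higher number that more compound is needed for the effect.

Compound 1, `CC(C)N(Cc1cccc(OCCCCCC(=O)O)c1)C(=O)c1ccc(-c2cccc(N(C)C)c2)cc1`: > 26000 nM, a limit of the assay.
Compound 2, `CC(C)N(Cc1cccc(OCCCCCC(=O)O)c1)C(=O)c1ccc(-c2ccoc2)cc1`: > 26000 nM, a limit of the assay.
Compound 3, `COc1cc(F)cc(-c2ccc(C(=O)N(Cc3cccc(OCCCCCC(=O)O)c3)C(C)C)cc2)c1`: > 26000 nM, a limit of the assay.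

Compound 2 stands at the assay limit in this assay, as do the two other values shown, and nothing in the numbers separates it from them. The step from compound 2 to compound 4, `CC(C)N(Cc1cccc(OCCCCCC(=O)O)c1)C(=O)c1ccc(-c2cccc(F)c2)cc1`, is 3-fluorophenyl in place of furan-3-yl on an aromatic carbon. Of the measured steps, a step that the two limits leave unreadable from compound 1 to compound 2 and a step that the two limits leave unreadable from compound 2 to compound 3 change the same position, and a step that the two limits leave unreadable from compound 1 to compound 3 likewise; each of them is unreadable, with a limit at both ends. the limit of > 26000 nM in this assay, at which 3 of the 3 values shown sit, is all the evidence the series gives. No readable step bears on the change, so no direction is expected in this assay beyond the scatter; the expectation is that compound 4 again sits at the limit. The step that the limit leaves unreadable from compound 2 to compound 4 is expected to be essentially none. Compound 4 is estimated at 40000 nM, with a range from 15000 nM to 150000 nM, most probably reported only as a limit.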

Compound 4, half-maximal effective concentration: > 26000 nM
Compound 4: no number, only a limit; the forecaster's own chance of this, stated with the estimate: 85%; the middle value does not contradict the limit.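

In this assay compound 4 gives > 26000 nM, a limit of the assay, and the steps linking it with compound 1, compound 2 and compound 3 cannot be read. The compounds shown leave open whether any substituent on the shared core gives a readable half-maximal effective concentration.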